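Aryl exchange on the saturated ring carbon: compound 3

The source may hold more compounds than are shown below. What is called first, only, known or untested is meant among the compounds shown, and "the series" means these compounds.

Two compounds of the series have numbers in an assay on Sf9 cells for inhibition of serine/threonine-protein kinase 4 (Homo sapiens), read by luminescence and ADP-Glo, with a stated time of 1 h, in the presence of a further agent that is not named here; on this read-out higher numbers stand for weaker inhibition and lower numbers for stronger inhibition. Compound 1 `CN1CC(=O)N(C)c2cnc(Nc3ccc(S(N)(=O)=O)cc3)nc21` carries hydrogen on the saturated ring carbon, and in this assay compound 1 gives 495 nM. Compound 2 `COc1cccc(C2C(=O)N(C)c3cnc(Nc4ccc(S(N)(=O)=O)cc4)nc3N2C)c1` bears a 3-methoxyphenyl at that position, and in this assay compound 2 gives 954 nM. Among the measured compounds shown here, compound 2 stands at the higher of the two numbers, but its only neighbour is compound 1 and the step of a 1.9-fold higher number from compound 1 to compound 2 (0.28 log units; within the scatter) does not rise above the scatter, so the two cannot be ordered.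

Compound 3 `CCc1ccccc1C1C(=O)N(C)c2cnc(Nc3ccc(S(N)(=O)=O)cc3)nc2N1C` has not been measured in this assay. The change is 2-ethylphenyl in place of 3-methoxyphenyl on a saturated ring carbon. For the measured compounds named here, the single measured step, a 1.9-fold higher number from compound 1 to compound 2 (0.28 log units; within the scatter), concerns the introduction of the aromatic group rather than an exchange of one for another, and it stayed within the scatter; no measured step tells what swapping the group does. The number for compound 3 is therefore expected close to that of compound 2, with a step of a 1.1-fold lower number from compound 2 to compound 3 (0.03 log units; within the scatter) not beyond the scatter. Compound 3 is estimated at 900 nM, with a range from 300 nM to 2700 nM.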

Compound 3, half-maximal inhibitory concentration: 51 nM
Beside the measured number, compound 3's estimate is 18-fold (1.25 log units) above it, outside the stated range (below it).
By their numbers in this assay, from the lowest: compound 3; then compounds 1 and 2 (each within the scatter of the next).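

In this assay, among the compounds shown here, the saturated ring carbon proves sensitive to which aryl group it carries: the exchange of 3-methoxyphenyl for 2-ethylphenyl gives a 19-fold lower number from compound 2 to compound 3 (1.27 log units; beyond the scatter), which is the first step beyond the scatter. Measured against hydrogen at the same carbon, 2-ethylphenyl gives a 9.7-fold lower number from compound 1 to compound 3 (0.99 log units; beyond the scatter), whereas 3-methoxyphenyl stayed within the scatter, so the presence of a six-membered aromatic ring at this position does not alone decide the number, and the two aryl groups, alike in heavy-atom count, are clearly separated. Nothing available here bears on the reason for this difference.

The exchange alters both the substituent on the phenyl ring and where it stands on that ring, and the compounds shown do not separate these two changes. Also open, going by these compounds, is whether unsubstituted phenyl, a longer chain such as propyl, or an amine on the phenyl ring would keep the lower number of compound 3, or return it to the level shared by the other two compounds.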